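Pyrrolidin-1-yl in place of (3-chlorophenyl)amino: two pairs

This account rests on a few compounds, and the source may have more. Where it says the series, first, only, none or still open, it means among the compounds named here.

The series rests on one shared core carrying either a (3-chlorophenyl)amino group or a pyrrolidin-1-yl group on a double-bonded ring carbon. Compound 3 `O=C1C(Nc2cccc(Cl)c2)=CC(=O)c2c1nc1n2[C@H]2OC[C@@H](O)[C@H]2OC1` bears the (3-chlorophenyl)amino group; in a functional assay on ECa-109 cells for inhibition, with ECa-109 cell line (Homo sapiens) as the target, read by sulforhodamine B assay (on this read-out lower numbers stand for stronger inhibition and higher numbers for weaker inhibition), compound 3 gives 3080 nM. Compound 2 `O=C1C=C(Nc2cccc(Cl)c2)C(=O)c2c1nc1n2[C@H]2OC[C@@H](O)[C@H]2OC1` carries the same atoms joined differently, and how the two cores differ is not broken down here; in this assay compound 2 gives 4690 nM, which lies within the scatter of the value for compound 3. Compound 1 `O=C1C(N2CCCC2)=CC(=O)c2c1nc1n2[C@H]2OC[C@@H](O)[C@H]2OC1` is the pyrrolidin-1-yl partner of compound 3. For compound 1 this assay reports only a limit, > 16000 nM, and this is the limit of > 16000 nM in this assay, at which 1 of the 3 values shown sits. The change from compound 3 to compound 1, (pyrrolidin-1-yl in place of (3-chlorophenyl)amino on a double-bonded ring carbon), thus produced an at least 5.1-fold higher number from compound 3 to compound 1 (0.71 log units; beyond the scatter).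

Compound 4 `O=C1C=C(N2CCCC2)C(=O)c2c1nc1n2[C@H]2OC[C@@H](O)[C@H]2OC1` has not yet been measured. Within the data shown here, its relation to compound 2 is pyrrolidin-1-yl in place of (3-chlorophenyl)amino on a double-bonded ring carbon, the same change as the one from compound 3 to compound 1, made on the core of compound 2. Because the step of an at least 5.1-fold higher number from compound 3 to compound 1 (0.71 log units; beyond the scatter) was already beyond the scatter and reached a limit, a step of similar size is expected here: from compound 2 to compound 4 the expected step is a 6.4-fold higher number from compound 2 to compound 4 (0.81 log units; beyond the scatter). On that basis compound 4 is estimated at 30000 nM in this assay, between 12000 nM and 80000 nM, and the result may well again be reported only as a limit.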

Compound 4, half-maximal inhibitory concentration: > 16000 nM
Compound 4: only a limit was reported (the forecaster's own chance of this, stated with the estimate: 75%); the middle value is on the limit's open side.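

In this assay, the change from (3-chlorophenyl)amino to pyrrolidin-1-yl gives an at least 3.4-fold higher number from compound 2 to compound 4 (0.53 log units; beyond the scatter), so on both cores shown the number rises beyond the scatter and inhibition weakens, with no pair among the two going against this. This shows that the direction of the change carries from one core to the other, but not that its size does: the same change on two cores in this assay, an at least 5.1-fold higher number (0.71 log units; beyond the scatter) from compound 3 to compound 1 and an at least 3.4-fold higher number (0.53 log units; beyond the scatter) from compound 2 to compound 4; the limit leaves it open whether they differ. The pyrrolidin-1-yl compounds, compound 1 and compound 4, are each reported only as a limit, so neither step has a known end point and the two pairs give no ranking of these compounds: the limit of > 16000 nM in this assay, at which 2 of the 4 values shown sit.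

The change replaces the aromatic ring and removes the hydrogen-bond donor in a single step, so these pairs cannot separate what each contributes to the (3-chlorophenyl)amino result. Still open, going by these compounds, is how phenylamino without the chlorine, benzylamino, an open-chain amine such as diethylamino, or a ring amine with a second hetero atom such as morpholin-4-yl would behave on either core, and whether any of these would give a measurable value rather than a limit.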